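The source may report more compounds than this note shows. Statements on the series, on what has been measured and on what is new or still open speak of the compounds shown alone.

Measured compounds in the series:

compound 1, `COc1cc(OC)c(Cc2coc3cc(O)cc(O)c3c2=O)c(OC)c1`: 49.5%
compound 2, `COc1ccccc1Cc1coc2cc(O)ccc2c1=O`: 28.8%
compound 3, `COc1cc(OC)c2c(=O)c(Cc3ccc(Cl)c(Cl)c3)coc2c1`: 21.5%

Among the compounds with values here, in an ADME assay on MCF7 cells (Homo sapiens) for inhibition, read by MTT assay, with a stated time of 72 h, tested at 50 uM (a higher number here means more inhibition at the concentration tested (going by the name of the read-out), a lower number less inhibition), compound 3 gives 21.5%, the lowest of the three numbers measured so far. Compound 2 gives 28.8%, a number that lies within the usual scatter of the value of compound 3, so the two cannot be ranked against each other. Compound 1 gives 49.5%, which stands beyond the scatter above compound 3 and is the only one of the three that clearly separates from it.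

The next compound to be measured is compound 4, `COc1cc(OC)c2c(=O)c(Cc3cccs3)coc2c1`. Compared with compound 3, the change is thiophen-2-yl in place of 3,4-dichlorophenyl on a saturated chain carbon bound to an aromatic carbon. Within the data shown here, no measured pair in the set differs by this change alone, so nothing in the data shows what it does to the read-out; the three measured compounds also differ from one another at several places at once, so no single step can be read from them.

For this assay the step from compound 3 to compound 4 is expected to be a number 1.5 percentage points higher from compound 3 to compound 4 (within the scatter), that is, no change beyond the scatter in either direction. The expected value for compound 4 in this assay is therefore 23%, with a range from 8% to 42%, which should be read as an estimate only.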

Compound 4, a percentage reported as inhibition, at one concentration (the size of the read-out at that concentration, not a potency): 46.6%
The estimate for compound 4 lay 23.6 percentage points below the measured number, and the stated range ends below it.
By their numbers in this assay, from the lowest: compounds 3 and 2 (each within the scatter of the next); then compounds 4 and 1 (each within the scatter of the next).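

In this assay, within the data shown here, thiophen-2-yl in place of 3,4-dichlorophenyl on a saturated chain carbon bound to an aromatic carbon gives a number 25.1 percentage points higher from compound 3 to compound 4 (beyond the scatter), the first step that can be read at a single place, and it shows that the read-out responds to the group at this position while the rest of the structure stays the same. The change swaps several things at once: 8 heavy atoms for 5, a six-membered aromatic ring of carbon only for a five-membered aromatic ring with 1 hetero atom, and 2 chlorine atoms for 1 sulfur atom, and this one step cannot separate them. Nothing measured alongside the read-out bears on why the number moves.

As far as these compounds go, it remains open whether the step follows from the ring, the sulfur or the loss of the chlorines, a question that an unsubstituted phenyl, a 4-chlorophenyl or a furan-2-yl group at the same place could help to divide. From the compounds shown here alone, it is also open whether the same change would give a step of similar size on the core of compound 1 or of compound 2, and whether a dimethylaminomethyl group at this position would give a higher, lower or level number.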